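A Smaller Amine on the Propyl Chain of Compound 2

This account rests on a few compounds, and the source may have more. Where it says the series, first, only, none or still open, it means among the compounds named here.

Among the compounds with values here, compound 2 `CCN1CCN(CCCn2cnc3c(N4CCN(C5CCCC5)CC4)nc(N)nc32)CC1` is one of two compounds measured in an assay on HEK293 cells for antagonist activity at Toll-like receptor 9 (Homo sapiens), read by spectrophotometry (on this read-out higher numbers stand for weaker inhibition and lower numbers for stronger inhibition), where compound 2 gives 280 nM. That is the highest of the two numbers; the other compound, compound 1 `CN(C)Cc1ccc(CNc2nc(N3CCN(C4CCCC4)CC3)c3ncn(CCCN4CCCC4)c3n2)cc1`, gives 7 nM in this assay, a gap that lies beyond the scatter. Compound 1 differs from compound 2 in more than one place, so the two values alone do not say which part of the structure carries the gap.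

Compound 3 `Nc1nc(N2CCN(C3CCCC3)CC2)c2ncn(CCCN3CCCC3)c2n1` has not yet been measured. It differs from compound 2 in a single place: pyrrolidin-1-yl in place of 4-ethylpiperazin-1-yl on a saturated chain carbon, three bonds along the chain from an aromatic nitrogen. Within the data shown here, no measured pair isolates this change, so the size of the step rests on expectation only. Compound 3 is expected to give a somewhat lower number than compound 2, with the step of a 1.9-fold lower number from compound 2 to compound 3 (0.27 log units; within the scatter) possibly no larger than the scatter. Compound 3 is estimated at 150 nM in this assay, between 40 nM and 500 nM.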

Compound 3, half-maximal inhibitory concentration: 120 nM
Compound 3: the middle estimate sits 1.3-fold (0.10 log units) above what was measured; measured number inside the range.
By their numbers in this assay, from the lowest: compound 1; then compound 3; then compound 2.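

In this assay, pyrrolidin-1-yl in place of 4-ethylpiperazin-1-yl on the propyl chain gives a 2.3-fold lower number from compound 2 to compound 3 (0.37 log units; beyond the scatter), so a modest step beyond the scatter can now be assigned to this position alone. Compound 3 also isolates the other site: hydrogen in place of 4-((dimethylamino)methyl)benzyl on a nitrogen on an aromatic ring gives a 17-fold higher number from compound 1 to compound 3 (1.23 log units; beyond the scatter), a large step that far exceeds the one on the chain. Nothing shown here explains either step.

Still open, going by these compounds, is whether another amine on the propyl chain, such as dimethylamino or morpholine, or a shorter chain in place of propyl, would lower the number further. On these data alone, it also remains open whether a plain benzyl on that nitrogen would keep the low number without the dimethylaminomethyl group.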